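Aromatic substituent change from compound 2 to compound 3

This account rests on a few compounds, and the source may have more. Where it says the series, first, only, none or still open, it means among the compounds named here.

Measured so far:
compound 1 `CC1=CC[C@H](C(C)(C)NC(=S)N/N=C/c2ccccc2)CC1`: 13000 nM in a functional assay on NCI-H460 cells (Homo sapiens) for inhibition, read by sulforhodamine B assay, with a stated time of 48 h; a higher number here means a weaker inhibitor of growth, a lower number a stronger inhibitor of growth
compound 2 `COc1ccc(/C=N/NC(=S)NC(C)(C)[C@H]2CC=C(C)CC2)cc1`: 22500 nM

Going by the values given here, compound 2 stands highest of the two numbers in this assay; its nearest neighbour is compound 1, and the single measured step, a 1.7-fold higher number from compound 1 to compound 2 (0.24 log units; within the scatter), lies within the scatter. Compound 3 `CC1=CC[C@H](C(C)(C)NC(=S)N/N=C/c2ccc(O)cc2)CC1` carries hydrogen in place of methyl on an oxygen on an aromatic ring. Among the compounds with values here, no measured step covers this change on the oxygen; the only step known concerns methoxy replacing hydrogen, and it was small. The step of a 1.3-fold lower number from compound 2 to compound 3 (0.12 log units; within the scatter) is therefore expected to stay within the scatter. Compound 3 is estimated at 17000 nM, in the range 7000 nM to 40000 nM.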

Compound 3, concentration for 50% growth inhibition: > 100000 nM
Compound 3 ended at the assay's limit; the forecaster's own chance of this, stated with the estimate: 5%; at least 5.8-fold (0.76 log units) between middle value and limit.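

In this assay compound 3 gives > 100000 nM as a limit of the assay, not a number: the limit of > 100000 nM in this assay, at which 1 of the 3 values shown sits. On the aromatic ring, hydroxy stands apart from both neighbours, with steps beyond the scatter (an at least 4.4-fold higher number from compound 2 to compound 3 (0.64 log units; beyond the scatter); an at least 7.6-fold higher number from compound 1 to compound 3 (0.88 log units; beyond the scatter)). Methoxy in place of hydrogen had stayed within the scatter (a 1.7-fold higher number from compound 1 to compound 2 (0.24 log units; within the scatter)), so this position is not indifferent to every substituent.

As far as these compounds go, the true size of both new steps stays unknown past the limit. From the compounds shown here alone, whether an amine, a carboxylic acid or an ethoxy group at this position tracks hydroxy or methoxy remains open.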